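A few compounds are considered here, and "the series" means these few. Any claim that something is new, unique, unknown or untested is made for them only; others in the source may bear on it.

Measured set:
Compound 1 `C=C[C@@](C)(/C=C/c1ccc(OC)cc1)CCC=C(C)C`: in a functional assay on Raji cells (Homo sapiens) for cytotoxicity, with a stated time of 72 h (on this read-out higher numbers stand for an effect only at larger amounts of compound and lower numbers for an effect already at smaller amounts), compound 1 gives > 26000 nM, a limit of the assay and not a number.
Compound 2 `C=C[C@@](C)(/C=C/c1ccc(O)cc1)CC/C=C/C#N`: in this assay compound 2 gives > 26000 nM, again a limit rather than a number.
Compound 3 `C=C[C@@](C)(/C=C/c1ccc(O)c(/C=C/c2ccc(F)cc2)c1)CCC=C(C)C`: in this assay compound 3 gives > 26000 nM, also a limit.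

Compound 1 thus stands nowhere in particular among the numbers shown: no compound of the series has a measured value, since the limit of > 26000 nM in this assay, at which 3 of the 3 values shown sit, covers every entry. Among the compounds with values here, no pair of measured compounds differs in a single place, so no measured step is available and nothing can be said yet about what any change on the ring does in this assay.

The compound still to be measured is compound 4 `C=C[C@@](C)(/C=C/c1ccc(-c2cccc(Br)c2)cc1)CCC=C(C)C`. Its difference from compound 1 is 3-bromophenyl in place of methoxy on an aromatic carbon. Because the limit of > 26000 nM in this assay, at which 3 of the 3 values shown sit, leaves compound 1 without a number, the step from compound 1 to compound 4 a step that the limit leaves unreadable from compound 1 to compound 4 is expected to be none beyond the scatter, and compound 4 is expected most likely to return only a limit as well. Compound 4 is accordingly estimated at 30000 nM, with a range from 8000 nM to 80000 nM.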

Compound 4, half-maximal effective concentration: > 26000 nM
Compound 4: no number, only a limit; the forecaster's own chance of this, stated with the estimate: 70%; the middle value is on the limit's open side.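

In this assay compound 4 gives > 26000 nM as a limit and not a number. The step from compound 1 to compound 4 cannot be read, so 3-bromophenyl in place of methoxy has no readable effect: the limit of > 26000 nM in this assay, at which 4 of the 4 values shown sit.

The compounds shown leave open whether any change to the shared core gives a measurable value in this assay at all.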